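Aryl versus phenethyl on the shared core in FM3A cells

The compounds below may be only part of what the source reports. "The series", "measured", "known", "first", "only" and "open" are said of these compounds alone.

Measured compounds:
Compound 1 `C=C(Br)C(=O)Nc1cccc(-c2cn3nc(-c4ccc(OCC)cc4)sc3n2)c1` gives 1100 nM in a functional assay on FM3A cells (Mus musculus) for inhibition, read by cell counting, with a stated time of 2 days; on this read-out lower numbers stand for stronger inhibition and higher numbers for weaker inhibition.
Compound 2 `C=C(Br)C(=O)Nc1cccc(-c2cn3nc(-c4ccc(C)cc4)sc3n2)c1` gives 1200 nM in this assay.
Compound 3 `C=C(Br)C(=O)Nc1cccc(-c2cn3nc(CCc4ccccc4)sc3n2)c1` gives 2600 nM in this assay.

Compound 3 carries the highest number of the three in this assay; its nearest neighbour is compound 2 and its furthest is compound 1, both beyond the scatter. The unmeasured compound 4 `C=C(Br)C(=O)Nc1cccc(-c2cn3nc(-c4ccc(OC)cc4)sc3n2)c1` differs from compound 3 in one place: 4-methoxyphenyl in place of phenethyl on an aromatic carbon. For the measured compounds named here, two measured steps bear on this change. Replacing the aryl group of compound 1 by phenethyl gave a 2.4-fold higher number from compound 1 to compound 3 (0.37 log units; beyond the scatter), and the same replacement from compound 2 gave a 2.2-fold higher number from compound 2 to compound 3 (0.34 log units; beyond the scatter). Compound 4 reverses this kind of change, putting an aryl group back where the phenethyl stood, with the 4-methoxyphenyl closest to the 4-ethoxyphenyl of compound 1. Compound 4 is therefore expected to show a modest step downward, a 2.4-fold lower number from compound 3 to compound 4 (0.37 log units; beyond the scatter), in this assay. Compound 4 is estimated at 1100 nM, with a range from 600 nM to 2200 nM.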

Compound 4, half-maximal inhibitory concentration: 890 nM
For compound 4 the middle estimate is 1.2-fold (0.09 log units) above the measured one; the measured number falls inside the stated range.
By their numbers in this assay, from the lowest: compounds 4, 1 and 2 (each within the scatter of the next); then compound 3.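

With a third aryl group in place of phenethyl, the pattern holds in this assay: the change gives a 2.9-fold lower number from compound 3 to compound 4 (0.47 log units; beyond the scatter) and runs the same way as the two earlier aryl comparisons, with no listed compound going against it. The 4-substituent on the aryl ring, by contrast, shows no measurable effect among these compounds: methoxy in place of methyl gives a 1.3-fold lower number from compound 2 to compound 4 (0.13 log units; within the scatter) and shortening ethoxy to methoxy gives a 1.2-fold lower number from compound 1 to compound 4 (0.09 log units; within the scatter) and both steps lie within the scatter. No evidence is available to explain the difference between the aryl compounds and compound 3.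

The compounds shown leave open how an unsubstituted phenyl, an amine or a carboxylic acid on the aryl ring would read. They also leave open whether a benzyl group or a chain longer than phenethyl would stay with compound 3 or join the aryl compounds.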